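A methoxy-bearing cinnamate ester on a diterpenoid core

The compounds below may be only part of what the source reports. "The series", "measured", "known", "first", "only" and "open" are said of these compounds alone.

Compound 1 `C=CC(=C)CC[C@@H]1[C@@]2(C)CCC[C@](C)(COC(=O)/C=C\c3ccc(O)cc3)[C@@H]2CC[C@@]1(C)O` is the only one of the three measured compounds that yields a number in a functional assay on MCF7 cells (Homo sapiens) for cytotoxicity, read by MTT assay, with a stated time of 48 h; a higher number here means a weaker inhibitor, a lower number a stronger inhibitor: compound 1 gives 15100 nM. Compound 2 `C=C[C@@]1(C)O[C@H]1C[C@H]1C(=C)CC[C@@H]2[C@]1(C)CCC[C@]2(C)C(=O)O` reaches only a limit of the assay in this assay, > 40000 nM. Compound 3 `C=C1CC[C@@H]2[C@](C)(CCC[C@]2(C)C(=O)O)[C@H]1C/C=C(\C)C=O` likewise stops at a limit in this assay, > 40000 nM. For the measured compounds named here, the single measured step, a step that the two limits leave unreadable from compound 2 to compound 3, therefore has no readable size, since both of its ends sit at the limit of > 40000 nM in this assay, at which 2 of the 3 values shown sit. Compound 4 `C=CC(=C)CC[C@@H]1[C@@]2(C)CCC[C@](C)(COC(=O)/C=C/c3ccc(O)c(OC)c3)[C@@H]2CC[C@@]1(C)O` differs from compound 1 in a single place: 2-(4-hydroxy-3-methoxyphenyl)ethenyl in place of 2-(4-hydroxyphenyl)ethenyl on a carbonyl carbon. Going by the values given here, no measured step touches this part of the ester, and the two limits give no guide to what such a change does, so it is expected to stay within the scatter, with the step from compound 1 to compound 4 estimated as a 1.2-fold lower number from compound 1 to compound 4 (0.07 log units; within the scatter). Compound 4 is accordingly expected to give about 13000 nM, within a range from 5000 nM to 35000 nM.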

Compound 4, half-maximal inhibitory concentration: 13500 nM
Compound 4: the middle estimate sits 1.0-fold (0.02 log units) below what was measured; measured number inside the range.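

The series now holds its first step of readable size, and it is a 1.1-fold lower number from compound 1 to compound 4 (0.05 log units; within the scatter) in this assay when 2-(4-hydroxy-3-methoxyphenyl)ethenyl replaces 2-(4-hydroxyphenyl)ethenyl on a carbonyl carbon. This place on the shared core therefore takes the larger group with no change beyond the scatter, and both compounds give a number rather than a limit of the assay. Nothing measured here gives a reason for this outcome.

Going by these compounds, it remains open whether an amine, a chlorine or an ethoxy group on the six-membered aromatic ring would move the number beyond the scatter. On these data alone, it is equally open what a saturated chain in place of the ethenyl link would do, so a single step at this place marks out no wider pattern.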